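The compounds below may be only part of what the source reports. "The series", "measured", "known", "first", "only" and "open" are said of these compounds alone.

Going by the values given here, in a functional assay on HT-29 cells (Homo sapiens) for inhibition, read by MTT assay, with a stated time of 120 h (a lower number here means a stronger inhibitor, a higher number a weaker inhibitor), compound 2 (`O=C(CCc1ccc(NC(=O)Nc2ccc(Cl)c(C(F)(F)F)c2)cc1)NC1CCC1`) gives 21300 nM, the only true number available so far. Compound 1 (`CNC(=O)/C(C)=C/c1ccc(NC(=O)Nc2ccc(Cl)c(C(F)(F)F)c2)cc1`) gives > 50000 nM, which is a limit and not a number. Compound 3 (`CNC(=O)CCc1ccc(NC(=O)Nc2ccc(Cl)c(C(F)(F)F)c2)cc1`) keeps the ethyl link of compound 2 but changes its amide end: methyl in place of cyclobutyl on an amide-type nitrogen. Among the compounds with values here, only one measured step bears on this. That step, an at least 2.3-fold lower number from compound 1 to compound 2 (0.37 log units; beyond the scatter), replaced the whole side chain at once, so it cannot isolate the amide end. Its methylcarbamoyl end does return in compound 3, so a modest rise in the number is expected in this assay, though it may stay close to the scatter. The expected size is a 1.4-fold higher number from compound 2 to compound 3 (0.15 log units; within the scatter). For compound 3 the estimated value is 30000 nM, with an expected range of 13000 nM to 50000 nM.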

Compound 3, half-maximal inhibitory concentration: 20600 nM
Beside the measured number, compound 3's estimate is 1.5-fold (0.16 log units) above it; measured number inside the range.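

In this assay, putting methyl in place of cyclobutyl on the amide-type nitrogen gives a 1.0-fold lower number from compound 2 to compound 3 (0.01 log units; within the scatter), so the two groups cannot be told apart at this position. With the methylcarbamoyl end now held the same, an at least 2.4-fold lower number from compound 1 to compound 3 (0.38 log units; beyond the scatter) isolates the rest of the side chain, which shows that the gap first seen with compound 2 does not depend on cyclobutyl. The value of compound 1 is a limit and not a number, so the full size of that step stays open: the limit of > 50000 nM in this assay, at which 1 of the 3 values shown sits.

The compounds shown do not separate the double bond of the prop-1-en-1-yl chain from its methyl branch. They also leave open whether a carboxylic acid in place of the amide, or a longer chain in place of the ethyl link, would give a clearly lower number.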